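A few compounds are considered here, and "the series" means these few. Any claim that something is new, unique, unknown or untested is made for them only; others in the source may bear on it.

Working notes on the series. Two compounds have numbers in a functional assay on PC-3 cells (Homo sapiens) for cytotoxicity, read by MTT assay, with a stated time of 72 h (on this read-out higher numbers stand for weaker inhibition and lower numbers for stronger inhibition), so far. Compound 1 `COCNc1n[n+]([O-])c2ccccc2[n+]1[O-]` gives 4270 nM in this assay, and compound 2 `[O-][n+]1nc(NCOC2CCCCC2)[n+]([O-])c2ccccc21` gives 6670 nM in this assay; the step from compound 1 to compound 2 a 1.6-fold higher number from compound 1 to compound 2 (0.19 log units; within the scatter), so compound 2 sits alongside compound 1 rather than apart from it.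

Compound 3 `[O-][n+]1nc(NCOCc2ccccc2)[n+]([O-])c2ccccc21` differs from compound 2 by benzyl in place of cyclohexyl on an oxygen on a saturated carbon. Within the data shown here, the only step bearing on this change is the one from compound 1 to compound 2, which stayed within the scatter. No step beyond the scatter is therefore expected for compound 3 in this assay, the estimated step being a 1.1-fold lower number from compound 2 to compound 3 (0.05 log units; within the scatter). For compound 3 the expected value is 6000 nM, with a range from 2500 nM to 15000 nM.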

Compound 3, half-maximal inhibitory concentration: 11900 nM
Beside the measured number, compound 3's estimate is 2.0-fold (0.30 log units) below it; low and high end bracket the measured number.
By their numbers in this assay, from the lowest: compounds 1, 2 and 3 (each within the scatter of the next, the first and the last beyond it).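

Benzyl in place of cyclohexyl on an oxygen on a saturated carbon gives a 1.8-fold higher number from compound 2 to compound 3 (0.25 log units; within the scatter) in this assay and so does not separate the aromatic ring from the saturated one. Phenyl in place of hydrogen on a saturated chain carbon bound to an oxygen on a saturated carbon gives a 2.8-fold higher number from compound 1 to compound 3 (0.45 log units; beyond the scatter) and is the first step at this position to pass the scatter, though only modestly. Nothing on hand accounts for either step. Whether an amine or a carboxylic acid at this position would give a number outside the range of these compounds stays open.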